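Nitro-to-methoxy swap on the aniline of compound 2

A few compounds are considered here, and "the series" means these few. Any claim that something is new, unique, unknown or untested is made for them only; others in the source may bear on it.

Measured so far:
compound 1, `Cc1ccc2nc(Nc3ccnc(Nc4ccc(S(C)(=O)=O)cc4)n3)sc2c1` — 1750 nM
compound 2, `Cc1cnc(Nc2ccc([N+](=O)[O-])cc2)nc1Nc1nc2ccccc2s1` — 6330 nM

Two compounds of the series carry a number in a functional assay on HCT-116 cells (Homo sapiens) for antiproliferative activity, read by MTT assay, with a stated time of 48 h; a lower number here means a stronger inhibitor, a higher number a weaker inhibitor. Compound 1 gives 1750 nM. Compound 2, with a different core and a nitro-bearing aniline, gives 6330 nM; this is the higher of the two numbers, and its gap to compound 1 is beyond the scatter. Among the compounds with values here, the two compounds differ in more than one place, so the pair shows only that compound 2 is the weaker inhibitor of the two, not which part of the structure accounts for it.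

Compound 3, `COc1ccc(Nc2ncc(C)c(Nc3nc4ccccc4s3)n2)cc1`, keeps the core of compound 2 and differs from it in one place: methoxy in place of nitro on an aromatic carbon.

Within the data shown here, no measured pair isolates this swap, so there is no step in this assay to lean on. The change is small in count and leaves the rest of the molecule untouched; a step of modest size is expected, more likely toward a lower number than a higher one, though a result within the scatter would not surprise. On that basis the estimated step from compound 2 to compound 3 is a 1.6-fold lower number from compound 2 to compound 3 (0.20 log units; within the scatter). For compound 3 the expected value in this assay is 4000 nM, with a range of 1500 nM to 12000 nM.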

Compound 3, half-maximal inhibitory concentration: > 50000 nM
Compound 3: no number, only a limit; the forecaster's own chance of this, stated with the estimate: 10%; middle value at least 12-fold (1.09 log units) away from the limit.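

In this assay compound 3 carries only a limit, > 50000 nM, and not a number. The change from 4-nitrophenyl to 4-methoxyphenyl is the only single-place change shown in the series, and the step is an at least 7.8-fold higher number from compound 2 to compound 3 (0.89 log units; beyond the scatter), beyond the scatter and in the direction of a weaker inhibitor, so the group at this place on the aniline is not a neutral choice for the antiproliferative read-out of the shared core. The printed size is only a lower bound on the step, and the true gap between the two compounds stays unknown: the limit of > 50000 nM in this assay, at which 1 of the 3 values shown sits.

A single pair cannot tell whether the nitro group supports the activity of compound 2 or the methoxy group takes activity away, and compound 1 cannot settle this, since it differs from both compounds in more than one place. An amine, a chlorine, a carboxylic acid or a plain hydrogen at the same place on the same core would show how the read-out follows the group there, and whether nitro is unusual among them or methoxy is.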